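A few compounds are considered here, and "the series" means these few. Any claim that something is new, unique, unknown or untested is made for them only; others in the source may bear on it.

Measured in a functional assay on BMMC cells (Mus musculus, strain C57BL/6) for inhibition, with stated times of 5 days and 48 h; a higher number here means a weaker inhibitor, a lower number a stronger inhibitor:

compound 1 `C=C1CC[C@@H]2[C@](C)(CNCc3ccccc3)[C@H](O)CC[C@@]2(C)[C@@H]1/C=C/C1=CCOC1=O`: 960 nM
compound 2 `C=C1CC[C@@H]2[C@](C)(CNCc3ccc(C)cc3)[C@H](O)CC[C@@]2(C)[C@@H]1/C=C/C1=CCOC1=O`: 740 nM
compound 3 `C=C1CC[C@@H]2[C@](C)(CNCc3cccc(OC)c3)[C@H](O)CC[C@@]2(C)[C@@H]1/C=C/C1=CCOC1=O`: 780 nM

Compound 3 stands second highest of the three numbers. Its nearest neighbour is reached by a 1.1-fold higher number from compound 2 to compound 3 (0.02 log units; within the scatter) and its furthest by a 1.2-fold lower number from compound 1 to compound 3 (0.09 log units; within the scatter), so all three measured compounds sit within the scatter of one another and no order among them can be read.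

Compound 4 `C=C1CC[C@@H]2[C@](C)(CNCc3ccc(OC)c(OC)c3)[C@H](O)CC[C@@]2(C)[C@@H]1/C=C/C1=CCOC1=O` has not yet been measured. It differs from compound 3 by methoxy in place of hydrogen on an aromatic carbon. Among the compounds with values here, two measured steps bear on this change. The closest match, a methoxy in place of hydrogen on an aromatic carbon, is a 1.2-fold lower number from compound 1 to compound 3 (0.09 log units; within the scatter), which lies within the scatter. The other substitution on the same aromatic ring, a methyl in place of hydrogen on an aromatic carbon, is a 1.3-fold lower number from compound 1 to compound 2 (0.11 log units; within the scatter), also within the scatter. Both show that adding a small group to this ring left the number essentially unchanged, and nothing in the set points to a different outcome for a second methoxy.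

Compound 4 is therefore expected to show a 1.1-fold lower number from compound 3 to compound 4 (0.05 log units; within the scatter), a step that stays within the scatter. The estimate for compound 4 in this assay is 700 nM, with a range from 350 nM to 1400 nM.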

Compound 4, half-maximal inhibitory concentration: 3740 nM
For compound 4 the middle estimate is 5.3-fold (0.73 log units) below the measured one; the measured number lies above the stated range.
By their numbers in this assay, from the lowest: compounds 2, 3 and 1 (each within the scatter of the next); then compound 4.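

In this assay, methoxy in place of hydrogen on this aromatic carbon, ortho to a methoxy group and para to a large group, is not neutral: the change gives a 4.8-fold higher number from compound 3 to compound 4 (0.68 log units; beyond the scatter) while the same type of change on the phenyl ring gave only a 1.2-fold lower number from compound 1 to compound 3 (0.09 log units; within the scatter) and so cannot be carried over from one place on the ring to another. Against the other two compounds the 3,4-dimethoxyphenyl group also stands apart, with a 3.9-fold higher number from compound 1 to compound 4 (0.59 log units; beyond the scatter) and a 5.1-fold higher number from compound 2 to compound 4 (0.70 log units; beyond the scatter), so this ring accepted the single added group of compound 2 or compound 3 within the scatter but does not accept the second methoxy of compound 4 in the same way. No measurement on hand accounts for this rise.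

Still open, as far as these compounds go, is whether the rise belongs to a methoxy on this carbon as such, which the 4-methoxyphenyl group would separate from the effect of having both methoxy groups together. Also open, from the compounds shown here alone, is whether a smaller replacement on the same carbon, such as fluorine or hydroxyl, keeps the number near that of compound 3 or moves it as the methoxy does.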